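Second chloro on the shared core: compound 3 to compound 4

A few compounds are considered here, and "the series" means these few. Any claim that something is new, unique, unknown or untested is made for them only; others in the source may bear on it.

Three compounds of this series have numbers in a functional assay on SN12C cells (Homo sapiens) for cytotoxicity, read by sulforhodamine B assay, with a stated time of 48 h; on this read-out lower numbers stand for stronger inhibition of growth and higher numbers for weaker inhibition of growth. Compound 1 `ClCc1ccccc1Cn1cnc2c(Cl)nc(Cl)nc21` gives 2040 nM. Compound 2 `ClCc1cccc(Cn2cnc3ncnc(Cl)c32)c1` gives 20400 nM. Compound 3 `ClCc1cccc(Cn2cnc3c(Cl)ncnc32)c1` gives 5120 nM, the second highest of the three numbers; its nearest neighbour is compound 1 at a lower number, beyond the scatter, and its furthest is compound 2 at a higher number, also beyond the scatter. No pair among these three differs in only one place, so no single step is counted.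

Compound 4 `ClCc1cccc(Cn2cnc3c(Cl)nc(Cl)nc32)c1` is not yet measured. Relative to compound 3 the change is chloro in place of hydrogen on an aromatic carbon, between two ring nitrogen atoms, meta to a chloro group. Compound 1 also carries two chloro groups on the shared core and shows a lower number, which is the only hint available. The expected step is a 2.0-fold lower number from compound 3 to compound 4 (0.31 log units; beyond the scatter), towards a lower number and modest in size. The estimate for compound 4 in this assay is 2500 nM, with a range from 1000 nM to 8000 nM.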

Compound 4, concentration for total growth inhibition: 4670 nM
For compound 4 the middle estimate is 1.9-fold (0.27 log units) below the measured one; the range from low to high includes it.
By their numbers in this assay, from the lowest: compound 1; then compounds 4 and 3 (each within the scatter of the next); then compound 2.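

In this assay chloro in place of hydrogen on this aromatic carbon, between two ring nitrogen atoms, gives a 1.1-fold lower number from compound 3 to compound 4 (0.04 log units; within the scatter) and so leaves no difference that can be told from the scatter. Going by these compounds alone, this is the only step in one place so far, and it shows that this carbon can carry chloro as well as hydrogen with no readable shift in growth inhibition, with the other chloro group in place. No measurement on hand offers an explanation for this flat step.

On these data alone, whether the flat result extends beyond chloro remains open, since an amine, a methoxy group or a carboxylic acid on the same carbon would test the position with quite different groups. Also open, as far as these compounds go, is whether the same step would read alike without the other chloro group, or with an amine in its place.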